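The source may hold more compounds than are shown below. What is called first, only, known or untested is meant among the compounds shown, and "the series" means these compounds.

Compound 3, `COc1cccc(/C=C/C(=O)c2sc(Nc3ccc(Cl)cc3)nc2C)c1`, was tested in a functional assay on Bel-7402 cells (Homo sapiens) for cytotoxicity, read by MTT assay; a lower number here means a stronger inhibitor, a higher number a weaker inhibitor. In this assay compound 3 gives only a limit, > 25000 nM, not a number. Its two neighbours fare the same. Compound 1, `COc1cccc(/C=C/C(=O)c2sc(Nc3ccc(Cl)c(Cl)c3)nc2C)c1`, gives a limit of > 25000 nM. Compound 2, `Cc1ccccc1Nc1nc(C)c(C(=O)/C=C/c2ccc(Cl)cc2)s1`, gives a limit of > 25000 nM. Among the measured compounds shown here, the one step measured among them, a step that the two limits leave unreadable from compound 1 to compound 3, cannot be read, since both of its ends are limits. What the three values do share is the limit of > 25000 nM in this assay, at which 3 of the 3 values shown sit.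

Compound 4, `Cc1nc(Nc2ccc(Cl)cc2)sc1C(=O)/C=C/c1ccc(Cl)cc1`, has not yet been measured. It differs from compound 3 in one place: 4-chlorophenyl in place of 3-methoxyphenyl on a double-bonded chain carbon bound to a double-bonded chain carbon. For the measured compounds named here, no measured step covers this exact change. Compound 2 already carries 4-chlorophenyl on a double-bonded chain carbon bound to a double-bonded chain carbon and still sits at the limit of > 25000 nM. Nothing among the three compounds points to a gain. Compound 4 is therefore expected to stay at the limit, a step that the limit leaves unreadable from compound 3 to compound 4 that means no change beyond the scatter. The estimate for compound 4 is 30000 nM, with a range from 10000 nM to 100000 nM.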

Compound 4, half-maximal inhibitory concentration: > 25000 nM
Compound 4: no number, only a limit; the forecaster's own chance of this, stated with the estimate: 80%; the middle value lies beyond the limit too.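

Compound 4 gives only a limit, as do compound 2 and compound 3, so neither step into compound 4 can be read. The four compounds share one result: the limit of > 25000 nM in this assay, at which 4 of the 4 values shown sit. They leave open which change to the shared core, if any, would give a measurable value.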